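The source may report more compounds than this note shows. Statements on the series, on what has been measured and on what is new or still open speak of the compounds shown alone.

Compound 1 `O=C(Nc1ccc(Sc2nc3ccccc3s2)c(Cl)c1)c1cccc(Br)c1O` and compound 2 `O=C(Nc1ccc(Sc2nc3ccccc3s2)cc1)c1cccc(Br)c1O` have been measured. In an assay on mitochondria for inhibition of HSP60/HSP10 (Homo sapiens) (a higher number here means a weaker inhibitor, a lower number a stronger inhibitor), compound 1 gives 7700 nM. In this assay compound 2 gives > 100000 nM, which is a limit of the assay and not a number. Compound 2 therefore sits at the limit of > 100000 nM in this assay, at which 1 of the 2 values shown sits.

Compound 3 `O=C(Nc1ccc(Sc2nc3ccccc3s2)cc1)c1cc(Br)cc(Br)c1O` differs from compound 2 by bromo in place of hydrogen on an aromatic carbon. Among the measured compounds shown here, the only measured step, an at least 12-fold higher number from compound 1 to compound 2 (1.11 log units; beyond the scatter), concerns a different ring and gives no direct reading on an entering bromo, so no step beyond the scatter is expected in this assay. Compound 3 is estimated at 100000 nM, within 30000 nM to 300000 nM, a step of a number no higher from compound 2 to compound 3 (the limit leaves the size open).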

Compound 3, half-maximal inhibitory concentration: 5900 nM
The estimate for compound 3 lay 17-fold (1.23 log units) above the measured number; the whole stated range lies above it.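

The position para to the hydroxy group responds strongly: in this assay, bromo in place of hydrogen there gives an at least 16-fold lower number from compound 2 to compound 3 (1.22 log units; beyond the scatter). Until now the only change shown was the chloro on the other ring, so this is the first sign that the 3-bromo-2-hydroxyphenyl side also matters. Compound 2 gives a limit of the assay and not a number: the limit of > 100000 nM in this assay, at which 1 of the 3 values shown sits.

Going by these compounds, whether a methyl, a methoxy or an amine at this position would serve like bromo stays open. So does whether this bromo and the chloro of compound 1 would add up in one compound.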